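From pyridin-4-yl to 4-fluorophenyl at a solubility limit

A few compounds are considered here, and "the series" means these few. Any claim that something is new, unique, unknown or untested is made for them only; others in the source may bear on it.

In a physicochemical assay for solubility, read by LC-MS, using the shake flask method, measured as thermodynamic solubility, with a stated time of 24 h, at pH 6.5 (a lower number here means a less soluble compound, a higher number a more soluble compound), compound 2 `OC[C@H]1O[C@H](OCCc2cn(-c3ccncc3)nn2)[C@@H](O)[C@@H](O)[C@@H]1O` gives > 3000 ug/mL, which is a limit and not a number. Compound 1 `O=[N+]([O-])c1ccc(-n2cc(CCO[C@H]3O[C@H](CO)[C@@H](O)[C@H](O)[C@@H]3O)nn2)cc1` gives > 3000 ug/mL, which is likewise a limit. What the measurements offer so far is therefore (the limit of > 3000 ug/mL in this assay, at which 2 of the 2 values shown sit). Within the data shown here, the only measured step, a step that the two limits leave unreadable from compound 1 to compound 2, puts pyridin-4-yl in place of 4-nitrophenyl on an aromatic nitrogen, and it has no readable size.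

Compound 3 `OC[C@H]1O[C@H](OCCc2cn(-c3ccc(F)cc3)nn2)[C@@H](O)[C@@H](O)[C@@H]1O` changes that same place, with 4-fluorophenyl in place of pyridin-4-yl on an aromatic nitrogen. Its new group, like the 4-nitrophenyl of compound 1, is a six-membered aromatic ring of carbon only. Among the measured compounds shown here, with no measured step to give a size, no step beyond the scatter is expected in this assay, although a number just short of the limit remains possible, and a report of a limit is the likeliest outcome. The expected change is an at least 1.0-fold lower number from compound 2 to compound 3 (0.02 log units; that floor lies within the scatter). For compound 3, the estimated solubility is 2800 ug/mL, with an expected range from 1200 ug/mL to 4000 ug/mL.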

Compound 3, solubility: > 3000 ug/mL
Compound 3 was reported as a limit; the forecaster's own chance of this, stated with the estimate: 65%; middle value at least 1.0-fold (0.02 log units) away from the limit.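

In this assay, compound 3 joins compound 1 and compound 2 as a reported limit, so neither new step, from compound 2 or from compound 1 to compound 3, can be read: the limit of > 3000 ug/mL in this assay, at which 3 of the 3 values shown sit.

The compounds shown leave open whether 4-nitrophenyl, pyridin-4-yl and 4-fluorophenyl on the aromatic nitrogen differ at all in this assay.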